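Phenyl for Hydroxy in a Cytotoxicity Series

The source may report more compounds than this note shows. Statements on the series, on what has been measured and on what is new or still open speak of the compounds shown alone.

Compound 1, `Cc1cc(C)c(S(=O)(=O)N2CCC(C3OCC(C)CO3)CC2)c(C)c1`, in an ADME assay on HCT-116 cells (Homo sapiens) for cytotoxicity, read by CellTiter-Glo, with a stated time of 72 h (on this read-out lower numbers stand for stronger inhibition and higher numbers for weaker inhibition), gives only a limit, > 5000 nM.
Compound 2, `Cc1cc(C)c(S(=O)(=O)N2CCC(N3CCC(O)CC3)CC2)c(C)c1`, in this assay gives only a limit, > 5000 nM.
Compound 3, `Cc1cc(C)c(S(=O)(=O)N2CCC(C(=O)N3CCC(C)CC3)CC2)c(C)c1`, in this assay gives only a limit, > 5000 nM.

Compound 2 thus stands at the limit, as do the two others; all three values are limits and none is a number. Every step among them is unreadable: a step that the two limits leave unreadable from compound 1 to compound 2, a step that the two limits leave unreadable from compound 1 to compound 3 and a step that the two limits leave unreadable from compound 2 to compound 3. Going by the values given here, the one piece of evidence is the limit of > 5000 nM in this assay, at which 3 of the 3 values shown sit.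

Compound 4, `Cc1cc(C)c(S(=O)(=O)N2CCC(N3CCC(c4ccccc4)CC3)CC2)c(C)c1`, differs from compound 2 by phenyl in place of hydroxy on a saturated ring carbon. Among the compounds with values here, no measured step bears on this change, and the steps that are measured give no readable size at all, so no direction beyond the scatter can be expected from them; the record simply shows the limit for compounds of this core.

Compound 4 is therefore expected to give 8000 nM in this assay, within 2000 nM to 30000 nM, most likely again only as a limit. The expected step is a step that the limit leaves unreadable from compound 2 to compound 4.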

Compound 4, half-maximal inhibitory concentration: > 5000 nM
Compound 4 gave a limit, no number (the forecaster's own chance of this, stated with the estimate: 70%); the middle value lies beyond the limit too.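

The values of compound 2 and compound 4 in this assay are both limits and not numbers, and the step between them, phenyl in place of hydroxy, cannot be read. The compounds shown leave open where the true value of any of them lies, and whether any change on the shared core would give a number: the limit of > 5000 nM in this assay, at which 4 of the 4 values shown sit.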